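The compounds below may be only part of what the source reports. "The series", "measured", "known", "first", "only" and "open" are said of these compounds alone.

Measured so far:
compound 1 `CCCNc1nc(N)c(C(=O)N=C(N)N)nc1Cl` — 24%
compound 2 `NC(N)=NC(=O)c1nc(Cl)c(NC2CCCCC2)nc1N` — 21%

In an assay for inhibition of acid-sensing ion channel 3 (Homo sapiens), read by patch clamp, tested at 1 uM (on this read-out higher numbers stand for more inhibition at the one concentration tested (going by the name of the read-out) and lower numbers for less inhibition), compound 1 gives 24% and compound 2 gives 21%. Within the data shown here, the one step between them, a number 3 percentage points lower from compound 1 to compound 2 (within the scatter), lies within the scatter, so the two compounds are not separated by this read-out; compound 2 holds the number that is not the higher of the two, but nothing more can be said of its standing against compound 1.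

Compound 3 `CCCN(C)c1nc(N)c(C(=O)N=C(N)N)nc1Cl` is the next case. It differs from compound 2 by methyl(propyl)amino in place of cyclohexylamino on an aromatic carbon. Among the measured compounds shown here, the only measured step, a number 3 percentage points lower from compound 1 to compound 2 (within the scatter), swapped one alkyl group for another on the same nitrogen and gave no change beyond the scatter. For the measured compounds named here, the step to compound 3 returns the propyl of compound 1 and adds a methyl on that nitrogen; no measured step covers a methyl there, so the expectation rests on the two compounds alone. The estimated step is a number 1 percentage points lower from compound 2 to compound 3 (within the scatter), with no movement beyond the scatter expected. Compound 3 is expected to give about 20% in this assay, within a range of 5% to 38%.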

Compound 3, a percentage reported as inhibition, at one concentration (the size of the read-out at that concentration, not a potency): 32%
Compound 3: middle estimate off by 12 percentage points, on the low side, within the range that was stated.
By their numbers in this assay, from the lowest: compounds 2, 1 and 3 (each within the scatter of the next, the first and the last beyond it).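

In this assay, the aromatic carbon ortho to a chloro group now shows a step beyond the scatter: methyl(propyl)amino in place of cyclohexylamino gives a number 11 percentage points higher from compound 2 to compound 3 (beyond the scatter) as a modest change, so the read-out does not treat every amino group at this position alike. Methyl in place of hydrogen on the nitrogen, with the propyl kept, gives a number 8 percentage points higher from compound 1 to compound 3 (within the scatter) and does not separate the two compounds, so a group with 0 hydrogen-bond donors stands level with the propylamino group of compound 1, which itself lies within the scatter of compound 2 as well. Nothing measured alongside these numbers accounts for the step beyond the scatter.

With only these compounds, the gap cannot be divided between the loss of the cyclohexyl ring and the added methyl, since compound 1 sits within the scatter of both ends. On these data alone, what dimethylamino, a longer chain such as methyl(butyl)amino, or a ring amine such as morpholine would give at this position stays open, and so does whether the modest step grows or fades along such a set.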